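The source may report more compounds than this note shows. Statements on the series, on what has been measured and on what is new or still open speak of the compounds shown alone.

Compound 1, `CC(C)CNC(=C\C(=O)/C=C/c1ccc(O)cc1)/C=C/c1ccc(O)cc1`: 100%
Compound 2, `COc1cc(/C=C/C(=O)/C=C(/C=C/c2ccc(OC(C)=O)c(OC)c2)NCC(C)C)ccc1OC(C)=O`: 96%
Compound 3, `CCC(C)NC(=C\C(=O)/C=C/c1ccc(O)cc1)/C=C/c1ccc(O)cc1`: 102%

All three were tested in a functional assay on Caco-2 cells (Homo sapiens), read by fluorescence, tested at 1 uM; a lower number here means a stronger effect, a higher number a weaker effect of the compound at the concentration tested. Compound 1 and compound 3 share a core and differ in one place: sec-butyl in place of isobutyl on an amine nitrogen. The step is a number 2 percentage points higher from compound 1 to compound 3 (within the scatter). Compound 2 has a different core from compound 1; the difference between the two cores is not broken down here. Compound 4, `CCC(C)NC(=C\C(=O)/C=C/c1ccc(OC(C)=O)c(OC)c1)/C=C/c1ccc(OC(C)=O)c(OC)c1`, has not been measured; it stands to compound 2 as compound 3 stands to compound 1: sec-butyl in place of isobutyl on an amine nitrogen. The place is the same in both pairs, so this is the same change.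

Because compound 2 gives 96% in this assay and the earlier step was a number 2 percentage points higher from compound 1 to compound 3 (within the scatter), the expected step is a number 2 percentage points higher from compound 2 to compound 4 (within the scatter). Compound 4 is therefore estimated at 98%, expected between 88% and 108%.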

Compound 4, a percentage reported as activity, at one concentration (the size of the read-out at that concentration, not a potency): 95%
Compound 4: the middle estimate sits 3 percentage points above what was measured, within the range that was stated.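

In this assay, sec-butyl in place of isobutyl on the amine nitrogen gives a number 1 percentage points lower from compound 2 to compound 4 (within the scatter) and the reading stays put on this second core. Set beside the earlier step, the change carries from one core to the other with no difference that can be told apart: the same change on two cores in this assay, a number 2 percentage points higher (within the scatter) from compound 1 to compound 3 and a number 1 percentage points lower (within the scatter) from compound 2 to compound 4, 3 percentage points apart, within the scatter of two such steps. Within the data shown here, this shows only that the swap leaves the reading within the scatter on both cores at one concentration; it does not show how a change with a real effect would carry over, nor how this one behaves on any further core.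

The compounds shown leave open whether a longer chain or a benzyl group on that nitrogen would move the reading at all.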